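The source may report more compounds than this note shows. Statements on the series, on what has been measured and on what is new or still open speak of the compounds shown alone.

Working notes on the series. In a functional assay on K562 cells (Homo sapiens) for antiproliferative activity, read by MTT assay, with a stated time of 48 h (on this read-out lower numbers stand for stronger inhibition and higher numbers for weaker inhibition), compound 1 `CNc1nc(Nc2cnn(CCCCCCC(=O)NO)c2)ncc1Cl` gives 590 nM and compound 2 `O=C(CCCCCn1cc(Nc2ncc(Cl)c(Nc3ccc(Cl)cc3)n2)cn1)NO` gives 490 nM so the two values stand within the scatter of each other. Compound 3 `O=C(CCCCCCn1cc(Nc2ncc(Cl)c(NC3CC3)n2)cn1)NO` differs from compound 1 by cyclopropyl in place of methyl on a nitrogen on an aromatic ring which reads in words as cyclopropyl in place of methyl on a nitrogen on an aromatic ring. Among the measured compounds shown here, no measured pair isolates this change, so in this assay no step beyond the scatter is expected, with a slight lean towards a lower number. The estimate amounts to a 1.3-fold lower number from compound 1 to compound 3 (0.12 log units; within the scatter) as the expected step. For compound 3 the estimated value is 450 nM with an expected range from 180 nM to 1100 nM for now.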

Compound 3, half-maximal inhibitory concentration: 380 nM
Compound 3: the middle estimate sits 1.2-fold (0.07 log units) above what was measured; the measured number falls inside the stated range.
By their numbers in this assay, from the lowest: compounds 3, 2 and 1 (each within the scatter of the next).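

In this assay, among the compounds shown here, this is the first pair to isolate the group on this nitrogen: cyclopropyl in place of methyl gives a 1.6-fold lower number from compound 1 to compound 3 (0.19 log units; within the scatter), so the three-membered non-aromatic ring is accommodated here without a step beyond the scatter. The pair shows this for one change on the shared core only, and nothing available points to a cause for the step.

Still open, going by these compounds, is whether a group carrying a hydroxyl, a carboxylic acid or a basic amine on this nitrogen would stay within the scatter of compound 1. A bulkier tert-butyl group is equally unresolved.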